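The compounds below may be only part of what the source reports. "The series", "measured", "known", "first", "only" and "open" are said of these compounds alone.

Measured compounds in the series:

- Compound 1, `COc1cccc(/C(=C\c2cn(C(C)=O)c3ccc(OCc4ccccc4)cc23)C(=O)O)c1`: in a functional assay on KB cells (Homo sapiens) for cytotoxicity, read by MTT assay, with a stated time of 72 h (on this read-out lower numbers stand for stronger inhibition and higher numbers for weaker inhibition), compound 1 gives > 100000 nM, a limit of the assay and not a number.
- Compound 2, `COc1cc(/C(=C\c2cn(C(C)=O)c3ccc(OCc4ccccc4)cc23)C(=O)O)cc(OC)c1OC`: compound 2 gives > 100000 nM, again a limit.
- Compound 3, `CC(=O)n1cc(/C=C(/C(=O)O)c2ccc(Cl)cc2)c2cc(OCc3ccccc3)ccc21`: compound 3 gives > 100000 nM, also a limit.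

Compound 2 therefore stands only at a limit, and the two further values shown sit at the same limit (the limit of > 100000 nM in this assay, at which 3 of the 3 values shown sit). None of the three compounds can be ordered against the others.

The unmeasured compound 4, `COc1cc(OC)cc(/C(=C\c2cn(C(C)=O)c3ccc(OCc4ccccc4)cc23)C(=O)O)c1`, differs from compound 2 by hydrogen in place of methoxy on an aromatic carbon; cut one bond further out this reads 3,4,5-trimethoxyphenyl to 3,5-dimethoxyphenyl.

Among the measured compounds shown here, the steps that bear on this aryl position are a step that the two limits leave unreadable from compound 1 to compound 2, a step that the two limits leave unreadable from compound 1 to compound 3 and a step that the two limits leave unreadable from compound 2 to compound 3. All three run between limits, so no size can be read from any of them, and nothing shows that a change on this aryl ring moves the read-out into the measurable range.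

Compound 4 is therefore expected to remain at the limit as well, with an estimate of 200000 nM and a range from 60000 nM to 1000000 nM. The step implied from compound 2 to compound 4 is expected to be a step that the limit leaves unreadable from compound 2 to compound 4, i.e. nothing readable.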

Compound 4, half-maximal inhibitory concentration: 30400 nM
The estimate for compound 4 lay 6.6-fold (0.82 log units) above the measured number; the whole stated range lies above it.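

In this assay, compound 4 is the first sign that the aryl ring on the double-bonded chain carbon can bring this series off the limit, which the unreadable steps among compound 1, compound 2 and compound 3 could not show: the limit of > 100000 nM in this assay, at which 3 of the 4 values shown sit.

Hydrogen in place of methoxy, at the ring carbon para to a large group, gives an at least 3.2-fold lower number from compound 2 to compound 4 (0.51 log units; beyond the scatter), while methoxy in place of hydrogen gives an at least 3.2-fold lower number from compound 1 to compound 4 (0.51 log units; beyond the scatter), so the read-out does not move in one direction with the number of methoxy groups. 3,5-Dimethoxyphenyl in place of 4-chlorophenyl gives an at least 3.2-fold lower number from compound 3 to compound 4 (0.51 log units; beyond the scatter).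

Going by these compounds, the true size of all three steps stays open, as each is bounded by a limit. Also open, on these data alone, is whether the two methoxy groups are specifically required, or whether ethoxy or an amine in their place would give a measurable number.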